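A Smaller Branch on the Shared Core: Compound 4 Expected

A few compounds are considered here, and "the series" means these few. Any claim that something is new, unique, unknown or untested is made for them only; others in the source may bear on it.

Of the compounds shown here, three have so far been tested in a functional assay on DU-145 cells (Homo sapiens) for cytotoxicity, read by MTT assay; on this read-out higher numbers stand for weaker inhibition and lower numbers for stronger inhibition. Compound 1 `CC(C)[C@H](NC(=S)NCc1ccccc1)c1nc2ccccc2[nH]1` gives 48500 nM, compound 2 `CC(C)C[C@H](NC(=S)NCc1ccccc1)c1nc2ccccc2[nH]1` gives 21100 nM, and compound 3 `CC(C)C[C@@H](NC(=S)Nc1cc(C(F)(F)F)cc(C(F)(F)F)c1)c1nc2ccccc2[nH]1` gives 16500 nM. Compound 3 shows the lowest of the three numbers; its gap to compound 2 lies within the usual scatter, so no order between those two can be stated, while compound 1 lies further off.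

One single-point change is known. The difference is isopropyl in place of isobutyl on a saturated chain carbon bound to an amide-type nitrogen and an aromatic carbon, and the measured step was a 2.3-fold higher number from compound 2 to compound 1 (0.36 log units; beyond the scatter). How the core of compound 3 differs from the core of compound 2 is not broken down here.

Compound 4 `CC(C)[C@@H](NC(=S)Nc1cc(C(F)(F)F)cc(C(F)(F)F)c1)c1nc2ccccc2[nH]1` has not yet been measured. It arises from compound 3 by the same change at the same place: isopropyl in place of isobutyl on a saturated chain carbon bound to an amide-type nitrogen and an aromatic carbon. Because compound 3 gives 16500 nM in this assay, and because the same change once gave a 2.3-fold higher number from compound 2 to compound 1 (0.36 log units; beyond the scatter), a similar rise in the number is expected. The step from compound 3 to compound 4 is estimated as a 2.2-fold higher number from compound 3 to compound 4 (0.34 log units; beyond the scatter). Compound 4 is thus expected to give about 36000 nM, most likely between 16000 nM and 80000 nM.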

Compound 4, half-maximal inhibitory concentration: 20200 nM
Estimate against measurement, compound 4: 1.8-fold (0.25 log units) above; the measured number falls inside the stated range.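

In this assay, putting isopropyl in place of isobutyl on the second core gives a 1.2-fold higher number from compound 3 to compound 4 (0.09 log units; within the scatter), so on this core the change has no effect that can be told apart from ordinary measurement noise. Set beside the earlier step on the other core, the new step cannot be said to differ from it: the same change on two cores in this assay, a 2.3-fold higher number (0.36 log units; beyond the scatter) from compound 2 to compound 1 and a 1.2-fold higher number (0.09 log units; within the scatter) from compound 3 to compound 4, 1.9-fold (0.27 log units) apart, within the scatter of two such steps. Going by these compounds alone, this means the two cores give no sign of responding differently to the change, but with only two pairs, one of them inside the scatter, it does not establish a rise that transfers reliably or a rule for the series.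

The compounds shown leave open how this chain carbon would respond to other groups, such as a methyl group, a longer chain or a chain ending in an amine. They also leave open whether the change would behave the same way on a third core.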